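The source may report more compounds than this note shows. Statements on the series, on what has been measured and on what is new or still open speak of the compounds shown alone.

The measured compounds:

compound 1, `CCc1cccc2c(OC)c(-c3occ(C)c3COC)ccc12` — 8.8 ug/mL
compound 2, `CCc1cccc2c(OC)c(-c3occ(C)c3COC(C)=O)ccc12` — a value reported as > 10 ug/mL
compound 3, `CCOc1c(-c2occ(C)c2COC)ccc2c(CC)cccc12` — 5.9 ug/mL

All three were tested in a functional assay on KBVIN cells (Homo sapiens) for cytotoxicity, read by MTT assay, with a stated time of 72 h; a higher number here means that more compound is needed for the effect, a lower number that less compound is needed. Compound 3 differs from compound 1 by methyl in place of hydrogen on a saturated chain carbon bound to an oxygen on an aromatic ring; the step is a 1.5-fold lower number from compound 1 to compound 3 (0.17 log units; within the scatter), so the two values cannot be ordered against each other. Compound 2 differs from compound 1 by acetyl in place of methyl on an oxygen on a saturated carbon. For compound 2 this assay gives only a limit, (the limit of > 10 ug/mL in this assay, at which 1 of the 3 values shown sits), and not a number. Accordingly the step is an at least 1.1-fold higher number from compound 1 to compound 2 (0.05 log units; that floor lies within the scatter); how far the true value of compound 2 lies beyond that floor is not known.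

Compound 4, `CCOc1c(-c2occ(C)c2COC(C)=O)ccc2c(CC)cccc12`, has not yet been measured. For the measured compounds named here, it differs from compound 3 by acetyl in place of methyl on an oxygen on a saturated carbon, which is the same change as the one from compound 1 to compound 2, made on the same place in the same surroundings. The cores of compound 3 and compound 4 differ from those of compound 1 and compound 2 by methyl in place of hydrogen on a saturated chain carbon bound to an oxygen on an aromatic ring. Going by the values given here, the only earlier instance of this change, in compound 2, ended at a limit. The step expected from compound 3 to compound 4 is therefore taken as a 1.5-fold higher number from compound 3 to compound 4 (0.18 log units; within the scatter), resting on compound 3 with 5.9 ug/mL and on an at least 1.1-fold higher number from compound 1 to compound 2 (0.05 log units; that floor lies within the scatter). Compound 4 is therefore expected to give about 9 ug/mL in this assay, with the estimate ranging from 5 ug/mL to 18 ug/mL, and there is a fair chance that only a limit is reported.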

Compound 4, concentration for half-maximal effect: 5.8 ug/mL
Compound 4: middle estimate off by 1.6-fold (0.19 log units), on the high side, within the range that was stated.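

In this assay, the new step is a 1.0-fold lower number from compound 3 to compound 4 (0.01 log units; within the scatter), so acetyl in place of methyl on an oxygen on a saturated carbon gives no readable difference on the core of compound 3, and nothing yet separates its outcome on this core from that on the core of compound 1: the same change on two cores in this assay, an at least 1.1-fold higher number (0.05 log units; that floor lies within the scatter) from compound 1 to compound 2 and a 1.0-fold lower number (0.01 log units; within the scatter) from compound 3 to compound 4; the limit leaves it open whether they differ. The second change, methyl in place of hydrogen on a saturated chain carbon bound to an oxygen on an aromatic ring, can be set beside its earlier instance in the same way, with the new step being an at least 1.7-fold lower number from compound 2 to compound 4 (0.23 log units; that floor lies within the scatter), and again no difference between the cores is established: the same change on two cores in this assay, a 1.5-fold lower number (0.17 log units; within the scatter) from compound 1 to compound 3 and an at least 1.7-fold lower number (0.23 log units; that floor lies within the scatter) from compound 2 to compound 4; the limit leaves it open whether they differ. Going by these compounds, this does not show that either change carries over from one core to another with the same size, since compound 2 has a limit and not a number, and the size of each step that involves it remains unknown: the limit of > 10 ug/mL in this assay, at which 1 of the 4 values shown sits.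

The compounds shown leave open how the series would respond to other groups on the saturated carbon in place of methoxy or acetoxy, such as a free hydroxyl, an amine or a carboxylic acid. They also leave open whether a longer chain on the oxygen on the aromatic ring would give a step that stands clear of the scatter in this assay.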